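The source may report more compounds than this note shows. Statements on the series, on what has been measured and on what is new or still open speak of the compounds shown alone.

Working notes on the series. The shared core of compound 1 `O=C(Nc1cc(-c2ccccc2)nn1-c1ccccc1)c1ccccc1` carries a plain benzoyl amide, and in a functional assay on cells for positive allosteric modulation of metabotropic glutamate receptor 5 (Rattus norvegicus), read by calcium flux (on this read-out higher numbers stand for an effect only at larger amounts of compound and lower numbers for an effect already at smaller amounts), compound 1 gives 203 nM. Compound 2 `O=C(Nc1cc(-c2ccccc2)nn1-c1ccccc1)c1ccc(OC(F)(F)F)cc1` gives 18 nM in this assay, and compound 3 `O=C(Nc1cc(-c2ccccc2)nn1-c1ccccc1)c1ccc(C(F)(F)F)cc1` gives 38 nM. Two steps fix the place of compound 3: the step of a 5.3-fold lower number from compound 1 to compound 3 (0.73 log units; beyond the scatter) and the step of a 2.1-fold higher number from compound 2 to compound 3 (0.32 log units; beyond the scatter). Compound 3 therefore sits second highest of the three numbers, separated from compound 2 by a modest step and from compound 1 by a larger one. The companion step an 11-fold lower number from compound 1 to compound 2 (1.05 log units; beyond the scatter) is the largest seen so far.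

Compound 4 `O=C(Nc1cc(-c2ccccc2)nn1-c1ccccc1)c1ccc(Cl)c(Cl)c1` is the next variation: 3,4-dichlorophenyl in place of 4-(trifluoromethyl)phenyl on a carbonyl carbon. Within the data shown here, no measured pair tests a change of this kind, so the only bearing comes indirectly from the steps from compound 1, which show that putting a group in place of hydrogen on that aromatic carbon lowers the number, and from the step from compound 2 to compound 3, which shows that exchanging one such group for another moves the number only modestly. Compound 4 is thus expected to land near compound 3, with the step of a 1.1-fold lower number from compound 3 to compound 4 (0.04 log units; within the scatter) estimated to stay within a modest range in either direction. The estimate for compound 4 in this assay is 35 nM, with a range from 10 nM to 120 nM.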

Compound 4, half-maximal effective concentration: 13 nM
The estimate for compound 4 lay 2.7-fold (0.43 log units) above the measured number, within the range that was stated.
By their numbers in this assay, from the lowest: compounds 4 and 2 (each within the scatter of the next); then compound 3; then compound 1.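

The change at this position is not limited to fluorinated groups: in this assay, the step of a 2.9-fold lower number from compound 3 to compound 4 (0.47 log units; beyond the scatter) shows that 3,4-dichlorophenyl in place of 4-(trifluoromethyl)phenyl on the carbonyl carbon gives a lower number beyond the scatter, even though the entering group has fewer heavy atoms and no fluorine. The step of a 16-fold lower number from compound 1 to compound 4 (1.19 log units; beyond the scatter) places the new group well below the plain phenyl of compound 1, and compound 4 at 13 nM stands within the scatter of compound 2 at 18 nM, so a chlorinated and a trifluoromethoxy-bearing ring cannot be ordered on these numbers. No measurement in hand accounts for the gain, and no explanation for it can be drawn from the data.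

The compounds shown leave open how much each chlorine contributes, since 3-chlorophenyl and 4-chlorophenyl do not appear among them. They also leave open how this position responds to an amine, a carboxylic acid or a longer chain on the ring, as every substituent shown here is a halogen or a fluorinated group.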